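A few compounds are considered here, and "the series" means these few. Any claim that something is new, unique, unknown or untested is made for them only; others in the source may bear on it.

Measured compounds:
Compound 1, `O=C1NCCN1c1ccc(S(=O)(=O)Nc2ccccc2)cc1`, gives 470 nM in a functional assay on MCF7 cells (Homo sapiens) for antiproliferative activity, read by sulforhodamine B assay, with a stated time of 48 h; on this read-out lower numbers stand for stronger inhibition and higher numbers for weaker inhibition.
Compound 2, `O=C1NCCN1c1ccc(S(=O)(=O)Nc2ccc(OC(F)F)cc2)cc1`, gives 760 nM in this assay.

Within the data shown here, compound 1 stands at one of two numbers that lie within the scatter of each other; the only measured step, a 1.6-fold higher number from compound 1 to compound 2 (0.21 log units; within the scatter), is itself within that scatter. Compound 3, `Cc1ccc(NS(=O)(=O)c2ccc(N3CCNC3=O)cc2)c(C)c1`, differs from compound 1 by 2,4-dimethylphenyl in place of phenyl on a sulfonamide nitrogen. Among the measured compounds shown here, no measured step adds methyl groups to this phenyl, so the single step bearing on it is the one from compound 1 to compound 2, which shows that a substituent on this ring need not move the number beyond the scatter. Compound 3 is therefore expected to stay near compound 1, with an estimated step of a 1.3-fold higher number from compound 1 to compound 3 (0.11 log units; within the scatter), giving an estimate of 600 nM with a range from 250 nM to 1500 nM.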

Compound 3, half-maximal inhibitory concentration: 230 nM
Beside the measured number, compound 3's estimate is 2.6-fold (0.42 log units) above it; measured number outside the range, below it.
By their numbers in this assay, from the lowest: compound 3; then compounds 1 and 2 (each within the scatter of the next).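

In this assay the change from phenyl to 2,4-dimethylphenyl on a sulfonamide nitrogen gives a 2.0-fold lower number from compound 1 to compound 3 (0.31 log units; beyond the scatter) and so moves the number beyond the scatter, which the difluoromethoxy step did not do. This shows that a substituent change at this place can shift the number, and that the shift can run toward stronger inhibition, though the step is modest. Nothing available explains this step. Still open, on these data alone, is whether a single methyl would give a similar step, and whether an amine or a carboxylic acid on this ring would move the number the same way.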